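Replacing the furan with tert-butyl on the shared core

This account rests on a few compounds, and the source may have more. Where it says the series, first, only, none or still open, it means among the compounds named here.

Measured so far:
Compound 2, `O=C(O)c1cccc(Cc2c(-c3ccoc3)nn3cc(Cl)ccc23)n1`, gives 130 nM in a functional assay on cells for antagonist activity at prostaglandin E2 receptor EP1 subtype (Rattus norvegicus), read by fluorescence and calcium flux, with a stated time of 60 s; a higher number here means a weaker inhibitor, a lower number a stronger inhibitor.
Compound 1, `O=C(O)c1cccc(Cc2c(-c3ccc(Cl)cc3)nn3cc(Cl)ccc23)n1`, gives 1100 nM in this assay.

Compound 2 stands lowest of the two numbers on this assay, meaning the stronger inhibitor, and its nearest neighbour is compound 1, which differs only in the group attached on the same aromatic carbon of the shared core. That single exchange, an 8.5-fold lower number from compound 1 to compound 2 (0.93 log units; beyond the scatter), shows that the group at this place matters.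

Compound 3, `CC(C)(C)c1nn2cc(Cl)ccc2c1Cc1cccc(C(=O)O)n1`, carries the change (tert-butyl in place of furan-3-yl on an aromatic carbon). Among the compounds with values here, no measured step puts tert-butyl, or any group without a ring, at this place, so the direction is open. Within the data shown here, only the step from compound 1 to compound 2 bears on it, and it says that swapping the group here can move the number well beyond the scatter in either direction. Since the furan-3-yl of compound 2 gave the best number seen, compound 3 is expected to be somewhat weaker, a step of a 3.1-fold higher number from compound 2 to compound 3 (0.49 log units; beyond the scatter), and compound 3 is estimated at 400 nM, within 100 nM to 2000 nM.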

Compound 3, half-maximal inhibitory concentration: 48 nM
Beside the measured number, compound 3's estimate is 8.3-fold (0.92 log units) above it; the whole stated range lies above it.
By their numbers in this assay, from the lowest: compound 3; then compound 2; then compound 1.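

In this assay, a group with no ring at this place, on an aromatic carbon of the five-membered aromatic ring with 2 nitrogen, gives the strongest inhibitor of the three compounds, so an aromatic ring here is not needed for activity: there is a 2.7-fold lower number from compound 2 to compound 3 (0.43 log units; beyond the scatter), and the exchange for 4-chlorophenyl is larger still, with a 23-fold lower number from compound 1 to compound 3 (1.36 log units; beyond the scatter). The tert-butyl group also has no hydrogen-bond acceptor, whereas furan-3-yl has one, so the acceptor on the furan-3-yl group is not required for inhibition at this level, and the two ring-bearing groups no longer mark the best result at this place. Nothing available gives a reason for these differences.

From the compounds shown here alone, what remains open is whether the number would fall further, hold or rise with a smaller branched chain such as isopropyl, a straight chain such as n-butyl, or a saturated ring such as cyclopropyl. It is also open how a nitrogen-bearing group such as an amine would behave here, since all three groups shown contain no nitrogen.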